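Ethoxy to methoxymethyl: compound 3 to compound 4

The source may report more compounds than this note shows. Statements on the series, on what has been measured and on what is new or still open speak of the compounds shown alone.

In a physicochemical assay for lipophilicity, read by HPLC, at pH 7 (a lower number here means a more polar compound, a higher number a more lipophilic compound), compound 3 `CCOc1cnc(N2CCC([C@H]3C[C@H]3COCc3ccc(S(C)(=O)=O)c(F)c3)CC2)nc1` reads 4.2 and is the highest of the three numbers available. Compound 1 `CC(C)c1noc(N2CCC([C@H]3C[C@H]3COCc3ccc(S(C)(=O)=O)cc3F)CC2)n1` gives 3.8 and compound 2 `CC1(OC(=O)N2CCC([C@H]3C[C@H]3COCc3ccc(-n4cnnn4)cc3F)CC2)CC1` gives 3.8 in the same measurement. Each of these two lies beyond the scatter under compound 3.

Compound 4 `COCc1cnc(N2CCC([C@H]3C[C@H]3COCc3ccc(S(C)(=O)=O)c(F)c3)CC2)nc1` differs from compound 3 in one substituent, with methoxymethyl in place of ethoxy on an aromatic carbon and the rest of the structure unchanged. The two have the same atoms, joined differently.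

Among the measured compounds shown here, no two measured compounds differ in one place. The three values therefore give no direct size for such a change, and the expectation rests on the structural change alone. A fall in this assay beyond the scatter is expected, estimated as a number 0.60 log units lower from compound 3 to compound 4 (beyond the scatter) for this single change. Compound 4 is estimated at 3.6 with an expected range from 3.2 to 4 in this measurement.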

Compound 4, distribution coefficient: 3.5
Compound 4: the middle estimate sits 0.10 log units above what was measured, within the range that was stated.
By their numbers in this assay, from the lowest: compounds 4, 1 and 2 (each within the scatter of the next); then compound 3.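

In this assay, among the compounds shown here, methoxymethyl in place of ethoxy gives a number 0.70 log units lower from compound 3 to compound 4 (beyond the scatter) and provides the first step between compounds that differ in one place. Ethoxy and methoxymethyl have the same heavy-atom count and the same hydrogen-bond donor and acceptor counts, and the two compounds have the same atoms joined differently, so at this position a rearrangement alone moves the reading beyond the scatter. No measurement shown here accounts for the size of this step.

From the compounds shown here alone, this is a single step at a single position, so whether the same exchange gives a similar step on the cores of compound 1 or compound 2 remains open. Going by these compounds, how an amine, a carboxylic acid or a longer ether chain such as propoxy would read at this aromatic carbon also remains open.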